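Rat Plasma Stability of Carbapenem Prodrug Esters

This account rests on a few compounds, and the source may have more. Where it says the series, first, only, none or still open, it means among the compounds named here.

Measured compounds:
Compound 1 `C[C@@H](O)[C@H]1C(=O)N2C(C(=O)OCOC(=O)C(C)(C)C)=C(S[C@@H]3CN[C@H](C(=O)Nc4cccc(C(=O)O)c4)C3)[C@H](C)[C@H]12`: 0%
Compound 2 `CCC(CC)C(=O)OCOC(=O)C1=C(S[C@@H]2CN[C@H](C(=O)Nc3cccc(C(=O)O)c3)C2)[C@H](C)[C@@H]2[C@@H]([C@@H](C)O)C(=O)N12`: 0%
Compound 3 `CC(C)OC(=O)OCOC(=O)C1=C(S[C@@H]2CN[C@H](C(=O)Nc3cccc(C(=O)OCOC(=O)OC(C)C)c3)C2)[C@H](C)[C@@H]2[C@@H]([C@@H](C)O)C(=O)N12`: 3%

In an ADME assay on a cell-free system (plasma, Rattus norvegicus) for metabolic stability, read by LC-MS, with a stated time of 60 min, at 37 degrees C, tested at 50 uM (a higher number here means that more of the compound is left, a lower number that less of the compound is left), compound 1 gives 0% and compound 2 gives 0%; the one step shown, no change at the digits printed from compound 1 to compound 2 (within the scatter), lies within the scatter. In this assay compound 3 gives 3%, a number within the scatter of the other two, so the three values are indistinguishable. Compound 4 `CC(C)OC(=O)OCOC(=O)C1=C(S[C@@H]2CN[C@H](C(=O)Nc3cccc(C(=O)O)c3)C2)[C@H](C)[C@@H]2[C@@H]([C@@H](C)O)C(=O)N12` differs from compound 3 by hydrogen in place of ((isopropoxycarbonyl)oxy)methyl on an oxygen next to a carbonyl group. No measured step covers this change, and the only step shown was flat, so no step beyond the scatter is expected in this assay. Compound 4 is expected to give 1% (range 0% to 10%), a step of a number 2 percentage points lower from compound 3 to compound 4 (within the scatter).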

Compound 4, percent of the compound remaining: 0%
For compound 4 the middle estimate is 1 percentage points above the measured one; the range from low to high includes it.
By their numbers in this assay, from the lowest: compounds 1, 2, 4 and 3 (each within the scatter of the next).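

In this assay the step of a number 3 percentage points lower from compound 3 to compound 4 (within the scatter) shows that ((isopropoxycarbonyl)oxy)methyl on this oxygen can be replaced by hydrogen with no difference beyond the scatter. The steps of no change at the digits printed from compound 2 to compound 4 (within the scatter) and no change at the digits printed from compound 1 to compound 4 (within the scatter) show the same for isopropoxy on a carbonyl carbon in place of pentan-3-yl or tert-butyl. No available evidence bears on why these values stay so close. Still open, going by these compounds, is whether a longer chain or an amine in place of isopropoxy on that carbonyl carbon would leave more compound in this assay at the end of the test.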